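This account rests on a few compounds, and the source may have more. Where it says the series, first, only, none or still open, it means among the compounds named here.

Measured in an assay for inhibition of beta-glucuronidase (Bos taurus), read by spectrophotometry, with a stated time of 30 min; on this read-out lower numbers stand for stronger inhibition and higher numbers for weaker inhibition:
compound 1 `COC(=O)C1=C(C)NC(=O)NC1c1ccccc1`: "not active" (no number reported)
compound 2 `COC(=O)C1=C(C)NC(=O)NC1c1cccc(O)c1`: 15200 nM

Compound 1 stands without a number: in this assay compound 1 gives "not active" (no number reported), while compound 2 gives a countable 15200 nM. Compound 3 `COC(=O)C1=C(C)NC(=O)NC1c1ccccc1OCc1ccccc1` differs from compound 1 by benzyloxy in place of hydrogen on an aromatic carbon. Among the compounds with values here, no step between measured compounds covers this change, so its size and direction remain open; a move from no reported number to a countable value is what seems plausible. Compound 3 is expected to give about 20000 nM in this assay, within 5000 nM to 100000 nM.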

Compound 3, half-maximal inhibitory concentration: "not active" (no number reported)
The entry for compound 3 holds no number; the estimate stays without a comparison.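

In this assay compound 1 and compound 3 both stand without a number, so no step can be read between them. Going by these compounds, what benzyloxy in place of hydrogen does to inhibition stays open. No evidence bears on this result.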